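The compounds below may be only part of what the source reports. "The series", "measured", "known", "first", "only" and "open" are said of these compounds alone.

Compound 3 `CCOC(=O)c1ccc(NC(=O)N[C@@H](C)c2ccccc2)cc1` gives 99% in an ADME assay on the whole organism with Oryza sativa as the target, tested at 0.1 uM (a higher number here means a weaker effect of the compound at the concentration tested, a lower number a stronger effect), and stands level with compound 1 `CCc1ccc(NC(=O)N[C@@H](C)c2ccccc2)cc1` at 99%, the two together the highest of the three numbers. Compound 2 `C[C@H](NC(=O)Nc1ccc(C(F)(F)F)cc1)c1ccccc1` gives 94% in this assay. The exchanges at this aromatic carbon have so far moved little: no change at the digits printed from compound 1 to compound 3 (within the scatter), a number 5 percentage points higher from compound 2 to compound 3 (within the scatter) and a number 5 percentage points lower from compound 1 to compound 2 (within the scatter) all lie within the scatter. Compound 4 `C[C@H](NC(=O)Nc1ccc(F)cc1)c1ccccc1` differs from compound 3 by fluoro in place of ethoxycarbonyl on an aromatic carbon. For the measured compounds named here, no measured step introduces fluoro at that carbon, so the measured steps give only an indirect guide; since all of them are flat, the expected step of a number 2 percentage points lower from compound 3 to compound 4 (within the scatter) in this assay is none beyond the scatter. Compound 4 is therefore estimated at 97% in this assay, with a range from 88% to 100%.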

Compound 4, a percentage reported as activity, at one concentration (the size of the read-out at that concentration, not a potency): 96%
Compound 4: the middle estimate sits 1 percentage points above what was measured; measured number inside the range.
By their numbers in this assay, from the lowest: compounds 2, 4, 1 and 3 (each within the scatter of the next).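

Fluoro, with 1 heavy atom against the 5 of ethoxycarbonyl, leaves this assay as flat at this aromatic carbon as the larger groups did: a number 3 percentage points lower from compound 3 to compound 4 (within the scatter) and a number 2 percentage points higher from compound 2 to compound 4 (within the scatter) and a number 3 percentage points lower from compound 1 to compound 4 (within the scatter) all lie within the scatter. Across the four groups shown, the size of the group at this carbon therefore does not separate the compounds in this read-out. Nothing available explains this flatness.

On these data alone, whether an amine, a carboxylic acid or a longer chain at this carbon would shift the number beyond the scatter remains open. Also open, as far as these compounds go, is whether a change elsewhere on the shared core would do so.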